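The source may hold more compounds than are shown below. What is called first, only, known or untested is meant among the compounds shown, and "the series" means these compounds.

Two compounds share one core, and they differ only in the aromatic group that sits on it. Compound 1 `Fc1ccc2nc(-n3ccnn3)n(C3CC3)c2c1` gives 9070 nM in an ADME assay on cells for inhibition of cytochrome P450 11B1, mitochondrial (Homo sapiens), read by HPLC, with a stated time of 60 min; on this read-out lower numbers stand for stronger inhibition and higher numbers for weaker inhibition. Compound 2 `Fc1ccc2nc(-c3cncnc3)n(C3CC3)c2c1` gives 5380 nM in this assay. For the measured compounds named here, the one step measured so far, a 1.7-fold lower number from compound 1 to compound 2 (0.23 log units; within the scatter), is the swap of a five-membered azole for a six-membered diazine; it stays within the scatter, so compound 2 holds the lowest of the two numbers without being separable from compound 1.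

Going by the values given here, compound 3 `Fc1ccc2nc(-c3cnccn3)n(C3CC3)c2c1` is the next point. pyrazin-2-yl in place of pyrimidin-5-yl on an aromatic carbon The change keeps the same atoms and only moves one ring nitrogen, so it is smaller than the one measured step, which itself did not leave the scatter. Among the compounds with values here, no measured step speaks directly to it. He therefore expects no step beyond the scatter in this assay, and the estimated step of a 1.0-fold higher number from compound 2 to compound 3 (0.01 log units; within the scatter) is meant as a flat one. For compound 3 he estimates 5500 nM, within a range from 2000 nM to 15000 nM.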

Compound 3, half-maximal inhibitory concentration: > 10000 nM
Compound 3 was reported as a limit (the forecaster's own chance of this, stated with the estimate: 5%); middle value at least 1.8-fold (0.25 log units) from the limit.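

Moving a single ring nitrogen, with pyrazin-2-yl in place of pyrimidin-5-yl, is the first change at this position that ends in a limit rather than a readable number, and the value of compound 3 in this assay is such a limit: the limit of > 10000 nM in this assay, at which 1 of the 3 values shown sits.

The steps that can be read are therefore floors only: an at least 1.8-fold higher number from compound 2 to compound 3 (0.26 log units; that floor lies within the scatter), and an at least 1.1-fold higher number from compound 1 to compound 3 (0.04 log units; that floor lies within the scatter). Both floors stay within the scatter, so the data set no order among the three compounds, but they also put no upper bound on either step, which means that a change keeping the same atoms and the same counts is not yet shown to be as small as its description suggests.

The compounds shown leave open how far compound 3 actually lies from compound 2, a question that a limit cannot settle. They also leave open what an amine or a carboxylic acid would do on this aromatic carbon, and whether a longer chain in place of the cyclopropyl group would shift the numbers in this assay.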